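Cytotoxicity of Two Measured Compounds and One Expected

The source may report more compounds than this note shows. Statements on the series, on what has been measured and on what is new or still open speak of the compounds shown alone.

compound 1, `CC1CCN(c2nc(Cc3c(F)cccc3F)cc(=O)[nH]2)CC1`: > 78000 nM
compound 2, `Cc1c(Cc2c(F)cccc2F)nc(N(C)C2CCCCC2)[nH]c1=O`: > 72000 nM

Both compounds were tested in an ADME assay on MT4 cells (Homo sapiens) for cytotoxicity, read by MTT assay, with a stated time of 4 days; a higher number here means that more compound is tolerated, a lower number that less compound is tolerated. For compound 1 the result is a limit of the assay, > 78000 nM, as stated in the limit of > 78000 nM in this assay, at which 1 of the 2 values shown sits. For compound 2 the result is likewise a limit, > 72000 nM, as stated in the limit of > 72000 nM in this assay, at which 1 of the 2 values shown sits. Compound 2 therefore stands at one of the two limits shown, and neither value is a number, so no step between the two measured compounds can be given; the two values simply show that both compounds are tolerated up to the highest concentration tested.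

Compound 3, `Cc1c(Cc2c(F)cccc2F)nc(N2CCN(C)CC2)[nH]c1=O`, has not yet been measured in this assay. It differs from compound 2 by 4-methylpiperazin-1-yl in place of cyclohexyl(methyl)amino on an aromatic carbon. Among the measured compounds shown here, with no measured step available, the size of the step from compound 2 to compound 3 cannot be derived from the data; the expectation is none beyond the scatter, with compound 3 most likely also reported as a limit. The expected step from compound 2 to compound 3 is a step that the limit leaves unreadable from compound 2 to compound 3. Compound 3 is thus estimated at 80000 nM, within 40000 nM to 200000 nM.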

Compound 3, half-maximal cytotoxic concentration: > 75000 nM
Compound 3 was reported as a limit; the forecaster's own chance of this, stated with the estimate: 80%; the middle value does not contradict the limit.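

In this assay, compound 2 and compound 3 are both reported only as limits, so no step can be read between them for 4-methylpiperazin-1-yl in place of cyclohexyl(methyl)amino. The compounds shown leave open where the half-maximal cytotoxic concentration of compound 1, compound 2 or compound 3 actually lies, and whether this exchange changes it at all.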